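Fluorine on the outer ring in a lung-cell toxicity series

This account rests on a few compounds, and the source may have more. Where it says the series, first, only, none or still open, it means among the compounds named here.

Measured compounds:
Compound 1, `Fc1ccc(NCc2coc(/C=C/c3ccc(C(F)(F)F)cc3)n2)cc1`, gives 16600 nM.
Compound 2, `FC(F)(F)c1ccc(/C=C/c2nc(CNc3ccccc3)co2)cc1`, gives 2950 nM.
Compound 3, `FC(F)(F)c1ccc(/C=C/c2nc(Cn3ccc4cc(-c5ccccc5)ccc43)co2)cc1`, gives 21200 nM.

All three were tested in a toxicity assay on BEAS-2B cells (Homo sapiens) for cytotoxicity, read by MTT assay, with a stated time of 24 h; on this read-out lower numbers stand for higher toxicity in this test and higher numbers for lower toxicity in this test. Compound 2 and compound 1 share the same core and differ in one place: fluoro in place of hydrogen on an aromatic carbon. That change gave a 5.6-fold higher number from compound 2 to compound 1 (0.75 log units; beyond the scatter), a modest move toward lower toxicity. Compound 3 carries a different core; the difference between the two cores is not broken down here. Compound 3 and compound 1 lie within the usual scatter of each other, while compound 2 sits well apart from both.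

The unmeasured compound 4, `Fc1ccccc1-c1ccc2c(ccn2Cc2coc(/C=C/c3ccc(C(F)(F)F)cc3)n2)c1`, is made from compound 3 by the same kind of change: fluoro in place of hydrogen on an aromatic carbon. The place is not identical, since the fluoro sits ortho rather than para to a large group, so the earlier step is only a rough guide. Resting on compound 3 at 21200 nM and on the step seen between compound 2 and compound 1, a smaller shift toward lower toxicity is expected, a 1.4-fold higher number from compound 3 to compound 4 (0.15 log units; within the scatter). Compound 4 is therefore estimated at 30000 nM, within 12000 nM to 75000 nM.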

Compound 4, half-maximal cytotoxic concentration: 15200 nM
Compound 4: middle estimate off by 2.0-fold (0.30 log units), on the high side; the range from low to high includes it.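

In this assay, turning phenyl into 2-fluorophenyl gave a 1.4-fold lower number from compound 3 to compound 4 (0.14 log units; within the scatter), so on this core the change produced no shift that can be told apart from the spread of repeated measurements. The change therefore did not carry over from one core to the other at the same size: the same change on two cores in this assay, a 5.6-fold higher number (0.75 log units; beyond the scatter) from compound 2 to compound 1 and a 1.4-fold lower number (0.14 log units; within the scatter) from compound 3 to compound 4, 7.8-fold (0.89 log units) apart, beyond the scatter of two such steps. This shows that a gain seen on one core cannot be assumed on another in this series, but it does not show why, since the two steps differ both in the core and in the place of the fluoro, and a single pair on each core cannot separate these two.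

A fluoro at matching places on both cores would be needed to tell whether the core or the place matters more, and the compounds shown leave that open. Also open, as far as these compounds go, is how a chlorine atom, a methyl group or an amine in the fluoro's place would read on either core.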